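The compounds below may be only part of what the source reports. "The series", "measured", "known", "first", "only" and "open" are said of these compounds alone.

Measured compounds:
compound 1, `C[Se]/C(=N\C(=O)c1cccs1)NC(=O)c1cccs1`: 3.4 nM
compound 2, `O=C(/N=C(/NC(=O)c1ccno1)[Se]Cc1ccccc1)c1ccno1`: 7800 nM
compound 3, `O=C(/N=C(/NC(=O)c1cccs1)[Se]Cc1ccccc1)c1cccs1`: 72500 nM

All three were tested in a functional assay on MCF7 cells (Homo sapiens) for cytotoxicity, read by MTT assay, with a stated time of 72 h; on this read-out higher numbers stand for weaker inhibition of growth and lower numbers for stronger inhibition of growth. Compound 1 and compound 3 share a core and differ in one place: hydrogen in place of phenyl on a saturated chain carbon bound to a selenium atom. That change gave a 21000-fold lower number from compound 3 to compound 1 (4.33 log units; beyond the scatter). Compound 2 has a different core from compound 3; the difference between the two cores is not broken down here. Compound 4, `C[Se]/C(=N\C(=O)c1ccno1)NC(=O)c1ccno1`, is not yet measured and stands to compound 2 as compound 1 stands to compound 3: hydrogen in place of phenyl on a saturated chain carbon bound to a selenium atom. The place is the same in both, so this is the same change. For compound 4 the expected step is a 3900-fold lower number from compound 2 to compound 4 (3.59 log units; beyond the scatter), smaller than the earlier one, because compound 2 already gives 7800 nM, a lower starting point than compound 3 with 72500 nM, and a single example of the change is a thin basis. The estimate for compound 4 is 2 nM, between 0.3 nM and 30 nM.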

Compound 4, concentration for 50% growth inhibition: 0.09 nM
Estimate against measurement, compound 4: 22-fold (1.35 log units) above, outside the stated range (below it).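

In this assay, the change from benzyl to methyl gives an 87000-fold lower number from compound 2 to compound 4 (4.94 log units; beyond the scatter), so on this second core the number again falls, and the step is again large. The size of the step does not carry over exactly, since the two steps differ by more than the scatter: the same change on two cores in this assay, a 21000-fold lower number (4.33 log units; beyond the scatter) from compound 3 to compound 1 and an 87000-fold lower number (4.94 log units; beyond the scatter) from compound 2 to compound 4, 4.1-fold (0.61 log units) apart, beyond the scatter of two such steps. Two cores are only a small sample, so this does not show that the step would hold on a further core, and these compounds do not tell why its size differs.

Still open, from the compounds shown here alone, is how other groups at the same place would behave, such as ethyl, a longer chain, or a chain ending in an amine or a carboxylic acid.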